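Swapping Halogens Where Three Compounds Show No Activity

The source may hold more compounds than are shown below. What is called first, only, known or untested is meant among the compounds shown, and "the series" means these compounds.

Of the compounds shown here, three that share one core have been tested in a functional assay on MCF7 cells (Homo sapiens) for antiproliferative activity, read by MTT assay, with a stated time of 48 h; a lower number here means a stronger inhibitor, a higher number a weaker inhibitor. Compound 1 `Cc1ccccc1-n1nncc1CN1C(=O)C2(C(C#N)=C(N)Oc3c(N)cc4nc5ccccc5nc4c32)c2ccccc21` reaches only a limit of the assay, > 50000 nM. Compound 2 `CCc1cccc(C)c1-n1nncc1CN1C(=O)C2(C(C#N)=C(N)Oc3c(N)cc4nc5ccccc5nc4c32)c2ccccc21` likewise stops at a limit, > 50000 nM. Between them lies a step that the two limits leave unreadable from compound 1 to compound 2. Compound 3 `N#CC1=C(N)Oc2c(N)cc3nc4ccccc4nc3c2C12C(=O)N(Cc1cnnn1-c1ccc(Cl)cc1Cl)c1ccccc12` also gives only a limit, > 50000 nM. All three values sit at the limit of > 50000 nM in this assay, at which 3 of the 3 values shown sit, so the steps a step that the two limits leave unreadable from compound 1 to compound 3 and a step that the two limits leave unreadable from compound 2 to compound 3 are equally unreadable. Compound 4 `N#CC1=C(N)Oc2c(N)cc3nc4ccccc4nc3c2C12C(=O)N(Cc1cnnn1-c1ccc(F)c(Cl)c1)c1ccccc12` carries 3-chloro-4-fluorophenyl in place of 2,4-dichlorophenyl on an aromatic nitrogen. For the measured compounds named here, no measured step gives a direction, so the expected step of a number no higher from compound 3 to compound 4 (the limit leaves the size open) is none beyond the scatter. Compound 4 is therefore expected to give 50000 nM, in the range 20000 nM to 100000 nM, with another limit the likeliest outcome.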

Compound 4, half-maximal inhibitory concentration: 17800 nM
For compound 4 the middle estimate is 2.8-fold (0.45 log units) above the measured one; the measured number lies below the stated range.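

For the compounds shown here, putting 3-chloro-4-fluorophenyl on the aromatic nitrogen gives the first readable number in this assay, with an at least 2.8-fold lower number from compound 3 to compound 4 (0.44 log units; beyond the scatter), an at least 2.8-fold lower number from compound 2 to compound 4 (0.44 log units; beyond the scatter) and an at least 2.8-fold lower number from compound 1 to compound 4 (0.44 log units; beyond the scatter). This shows that the group at this position can change the result, even though the earlier swaps there could not be read. Each step is only a minimum, as the other compounds all stop at a limit: the limit of > 50000 nM in this assay, at which 3 of the 4 values shown sit.

The change from compound 3 alters both the halogens and their placement, and the compounds shown do not separate the two. From the compounds shown here alone, what a phenyl ring with a single fluorine or a single chlorine would give stays open, as does a phenyl ring carrying a methoxy group or an amine.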